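The compounds below may be only part of what the source reports. "The series", "measured", "known", "first", "only" and "open" are said of these compounds alone.

Of the compounds shown here, two built on a shared core have been tested so far. Compound 1 `NS(=O)(=O)c1cc(-c2nnc(CN3CCN(c4ccc(Cl)cc4)CC3)o2)c(Cl)cc1SCc1ccccc1` gives, in a functional assay on HeLa cells (Homo sapiens) for cytotoxicity, read by MTT assay, with a stated time of 72 h (a lower number here means a stronger inhibitor, a higher number a weaker inhibitor), a value of 11000 nM. Compound 2 `NC(=O)c1cn(Cc2nnc(-c3cc(S(N)(=O)=O)c(SCc4ccccc4)cc3Cl)o2)nn1` gives in this assay a value of 75000 nM. Compound 2 therefore stands with the highest number of the two, and its nearest neighbour, compound 1, lies well beyond the usual scatter from it.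

Compound 3 `NS(=O)(=O)c1cc(-c2nnc(/C=C/c3ccc(Cl)cc3)o2)c(Cl)cc1SCc1ccccc1` has not yet been measured in this assay. It differs from compound 2 in one place: 2-(4-chlorophenyl)ethenyl in place of (4-carbamoyl-1H-1,2,3-triazol-1-yl)methyl on an aromatic carbon. The (4-carbamoyl-1H-1,2,3-triazol-1-yl)methyl group is carried by compound 2 alone among the measured compounds, and compound 2 also carries the highest number. On that ground the change is expected to move the number downward rather than upward, by a step beyond the scatter, bringing compound 3 nearer to the value of compound 1. Compound 3 is therefore estimated at 10000 nM in this assay, within a range from 3000 nM to 40000 nM. The step this estimate means is a 7.5-fold lower number from compound 2 to compound 3 (0.88 log units; beyond the scatter).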

Compound 3, half-maximal inhibitory concentration: 40000 nM
The estimate for compound 3 lay 4.0-fold (0.60 log units) below the measured number; the measured number falls inside the stated range.
By their numbers in this assay, from the lowest: compound 1; then compounds 3 and 2 (each within the scatter of the next).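

In this assay, putting 2-(4-chlorophenyl)ethenyl in place of (4-carbamoyl-1H-1,2,3-triazol-1-yl)methyl gives a 1.9-fold lower number from compound 2 to compound 3 (0.27 log units; within the scatter), so at this aromatic carbon a group with one six-membered aromatic ring of carbon only and no hydrogen-bond donors or acceptors cannot be told apart from one with a five-membered aromatic ring and both kinds of hydrogen-bond group. The earlier compounds shown here left the (4-carbamoyl-1H-1,2,3-triazol-1-yl)methyl group as the only feature seen with the highest number, but this pair gives no sign that the group sets that number apart. No measurement shown here accounts for this result.

As far as these compounds go, whether a carboxylic acid or a simple amine such as morpholine at this place would give a number clearly apart from that of compound 2 remains open. The same holds for a 2-(4-chlorophenyl)ethyl chain, which would show whether the double bond of the 2-(4-chlorophenyl)ethenyl group matters in this assay.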